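A few compounds are considered here, and "the series" means these few. Any claim that something is new, unique, unknown or untested is made for them only; others in the source may bear on it.

Compound 1 `Cn1c(=O)c(=O)n(C2CCCC2)c2nc(N/N=C/c3ccc(Cl)cc3)ncc21` stands lowest of the three numbers in a functional assay on HCT-116 cells (Homo sapiens) for antiproliferative activity, read by MTT assay (on this read-out higher numbers stand for weaker inhibition and lower numbers for stronger inhibition), where compound 1 gives 9810 nM. Compound 2 `Cn1c(=O)c(=O)n(C2CCCC2)c2nc(N/N=C/c3ccc(S(C)(=O)=O)cc3)ncc21` gives 86600 nM in this assay, and compound 3 `Cn1c(=O)c(=O)n(C2CCCC2)c2nc(N/N=C/c3ccc(O)c(F)c3)ncc21` gives 59300 nM. Both departures from compound 1 at the aryl group raised the number: an 8.8-fold higher number from compound 1 to compound 2 (0.95 log units; beyond the scatter), and a 6.0-fold higher number from compound 1 to compound 3 (0.78 log units; beyond the scatter). Between the two weaker compounds the difference is small, a 1.5-fold lower number from compound 2 to compound 3 (0.16 log units; within the scatter), so the two replacements of 4-chlorophenyl cannot be told apart in this assay.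

Compound 4 `Cn1c(=O)c(=O)n(C2CCCC2)c2nc(N/N=C/c3ccc(F)cc3Cl)ncc21` carries the change (2-chloro-4-fluorophenyl in place of 4-chlorophenyl on a carbon with a double bond to nitrogen). Neither measured step covers this change: compound 2 and compound 3 both give up the chloro altogether, while compound 4 keeps a chloro and adds a fluoro to the same ring. The two measured steps therefore bear on compound 4 only loosely, showing that every change so far at this ring moved the number upward from compound 1 by a modest amount. A step of similar direction but smaller size is expected here, likely near or just beyond the scatter; a number lower than compound 1 is considered less likely. Compound 4 is estimated at 15000 nM in this assay, with a range from 5000 nM to 45000 nM, which means an expected step of a 1.5-fold higher number from compound 1 to compound 4 (0.18 log units; within the scatter).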

Compound 4, half-maximal inhibitory concentration: 13800 nM
Beside the measured number, compound 4's estimate is 1.1-fold (0.04 log units) above it; the measured number falls inside the stated range.
By their numbers in this assay, from the lowest: compounds 1 and 4 (each within the scatter of the next); then compounds 3 and 2 (each within the scatter of the next).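

In this assay, the aryl group on the carbon with a double bond to nitrogen accepts one further change without a readable shift: a 1.4-fold higher number from compound 1 to compound 4 (0.15 log units; within the scatter), so 2-chloro-4-fluorophenyl cannot be told apart from 4-chlorophenyl. The same ring stands well clear of the other two replacements, with a 4.3-fold lower number from compound 3 to compound 4 (0.63 log units; beyond the scatter) and a 6.3-fold lower number from compound 2 to compound 4 (0.80 log units; beyond the scatter), so among these four compounds the two lower numbers belong to the rings that keep a chloro, and no listed compound goes against this. The fluoro in compound 3 does not come with a low number, which shows that a fluoro on this ring is not enough by itself, and no measurement at hand accounts for the split between the chloro-bearing rings and the others.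

As far as these compounds go, whether the chloro itself goes with the lower numbers stays open, as a ring with a bromo or a methyl in its place would be needed to test it. From the compounds shown here alone, what an amine or a carboxylic acid on this ring would give also stays open, as does the effect of any change made elsewhere on the shared core.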